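Compound 4: Longer Chain and a Swapped End Group

A few compounds are considered here, and "the series" means these few. Any claim that something is new, unique, unknown or untested is made for them only; others in the source may bear on it.

The measured compounds, in a functional assay on the whole organism (stomach) with Rattus norvegicus as the target; a higher number here means that more compound is needed for the effect, a lower number that less compound is needed:
compound 1 `N#CNC(=N)NCCCCn1nc(-c2ccccc2)ccc1=O` gives 77.2 mg/kg
compound 2 `CC/N=C(\S)NCCCn1nc(-c2ccccc2)ccc1=O` gives only a limit, > 100 mg/kg
compound 3 `CC/N=C(\S)NCCCCn1nc(-c2ccccc2)ccc1=O` gives 37.2 mg/kg

Compound 3 stands lowest of the two numbers in this assay; the nearest is compound 1, at a 2.1-fold lower number from compound 1 to compound 3 (0.32 log units; beyond the scatter). Compound 2 sits at a limit of the assay (the limit of > 100 mg/kg in this assay, at which 1 of the 3 values shown sits), so it gives no number.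

Compound 4 `N#CNC(=N)NCCCCCn1nc(-c2ccccc2)ccc1=O` has not yet been measured. It differs from compound 3 in this way: a group of 7 heavy atoms (3 carbon, 4 nitrogen; no ring) in place of a group of 6 heavy atoms (3 carbon, 2 nitrogen, 1 sulfur; no ring), on a saturated chain carbon, four bonds along the chain from an aromatic nitrogen.

Going by the values given here, two measured steps bear on it. The step of a 2.1-fold lower number from compound 1 to compound 3 (0.32 log units; beyond the scatter) runs in the opposite sense to the present exchange of end groups, so reversing it should raise the number by a modest amount. The step of an at least 2.6-fold lower number from compound 2 to compound 3 (0.42 log units; beyond the scatter) shows that lengthening the chain lowered the number by at least a modest amount, and compound 4 carries the chain one bond longer again. The two pulls oppose each other, and the outcome is uncertain. The estimate for compound 4 is 60 mg/kg, with a range from 25 mg/kg to 150 mg/kg. This expected step, a 1.6-fold higher number from compound 3 to compound 4 (0.21 log units; within the scatter), lies close to the scatter and is not expected clearly in either direction.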

Compound 4, dose for half-maximal effect: > 100 mg/kg
Compound 4: a limit, no number; the forecaster's own chance of this, stated with the estimate: 15%; middle value at least 1.6-fold (0.22 log units) from the limit.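

In this assay compound 4 gives only a limit, not a number: the limit of > 100 mg/kg in this assay, at which 2 of the 4 values shown sit. With the group of 7 heavy atoms (3 carbon, 4 nitrogen) on a saturated chain carbon, four bonds along the chain from an aromatic nitrogen, the readable steps are floors: an at least 2.6-fold higher number from compound 3 to compound 4 (0.42 log units; beyond the scatter) and an at least 1.2-fold higher number from compound 1 to compound 4 (0.11 log units; that floor lies within the scatter), the second of which shows no clear change from the shorter chain of compound 1, while the first shows that this longer chain does not restore the low number of compound 3. The exchange of end groups and chain length therefore does not behave as one simple shift across the shared core, as the same change gives clearly different results in two settings: the same change on two cores in this assay, an at least 1.2-fold higher number (0.11 log units; that floor lies within the scatter) from compound 1 to compound 2 and an at least 2.6-fold lower number (0.42 log units; beyond the scatter) from compound 4 to compound 3, at least 3.4-fold (0.54 log units) apart, beyond the scatter of two such steps.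

The step from compound 2 to compound 4 cannot be read: both stand at limits. Open remains whether a still longer chain, or an amine or a carboxylic acid at the end of the chain, would bring the number in this assay down again.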